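The source may report more compounds than this note shows. Statements on the series, on what has been measured and on what is new or still open speak of the compounds shown alone.

Compound 1 `COc1ccc(-c2nc(C(F)(F)F)ccc2CNC(=O)C(C)c2ccc(NS(C)(=O)=O)c(F)c2)cc1F` gives 4.2 nM in an assay on CHO cells for antagonist activity at transient receptor potential cation channel subfamily V member 1 (Homo sapiens), read by FLIPR; on this read-out higher numbers stand for weaker inhibition and lower numbers for stronger inhibition. Compound 2 `CC(C(=O)NCc1ccc(C(F)(F)F)nc1-c1ccco1)c1ccc(NS(C)(=O)=O)c(F)c1` gives 5.8 nM in this assay, sitting alongside compound 1, because the step of a 1.4-fold higher number from compound 1 to compound 2 (0.14 log units; within the scatter) lies within the scatter. Compound 3 `CC(C(=O)NCc1ccc(C(F)(F)F)nc1-c1ccoc1)c1ccc(NS(C)(=O)=O)c(F)c1` differs from compound 2 at a single aromatic carbon: furan-3-yl in place of furan-2-yl on an aromatic carbon. Among the compounds with values here, the only measured step, a 1.4-fold higher number from compound 1 to compound 2 (0.14 log units; within the scatter), exchanged a whole ring at this same carbon and barely moved the number, so replacing furan-2-yl with furan-3-yl is expected to shift this assay by no more than the scatter, in no particular direction. Compound 3 is therefore estimated at 6.5 nM, between 2.5 nM and 17 nM, an expected step of a 1.1-fold higher number from compound 2 to compound 3 (0.05 log units; within the scatter).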

Compound 3, inhibition constant: 1.4 nM
Beside the measured number, compound 3's estimate is 4.6-fold (0.67 log units) above it; the whole stated range lies above it.
By their numbers in this assay, from the lowest: compound 3; then compounds 1 and 2 (each within the scatter of the next).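

Moving the attachment point of the same furan ring matters at this position: in this assay the change gives a 4.1-fold lower number from compound 2 to compound 3 (0.62 log units; beyond the scatter) even though both groups have the same atoms and the same counts. Furan-3-yl also separates from the larger ring, with a 3.0-fold lower number from compound 1 to compound 3 (0.48 log units; beyond the scatter) in the same read-out, whereas furan-2-yl stayed within the scatter of that ring. Nothing available here accounts for this difference.

Still open, as far as these compounds go, is whether thiophen-3-yl or a pyrazole would match furan-3-yl on this aromatic carbon. How an amine or a methyl group would fare there is also unknown.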